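The source may hold more compounds than are shown below. What is called first, only, known or untested is meant among the compounds shown, and "the series" means these compounds.

Measured compounds:
- compound 1, `CCCCCCCCc1ccc(OCC(=O)Cn2nnc(-c3cccnc3)n2)cc1`, 23 nM
- compound 2, `CCCCCCCCc1ccc(OCC(=O)Cn2nnc(-c3ccccn3)n2)cc1`, 18 nM
- compound 3, `CCCCCCCCc1ccc(OCC(=O)Cn2nnnc2-c2cccnc2)cc1`, 190 nM

All three were run in an assay on microsomes from brain for inhibition of Fatty-acid amide hydrolase 1 (Rattus norvegicus), read by fluorescence and HPLC, with a stated time of 60 min; on this read-out higher numbers stand for weaker inhibition and lower numbers for stronger inhibition. Compound 1 and compound 2 share one core and differ only in the pyridyl group: pyridin-2-yl in place of pyridin-3-yl on an aromatic carbon. The step of a 1.3-fold lower number from compound 1 to compound 2 (0.11 log units; within the scatter) is within the scatter, so the two values cannot be ordered. Compound 3 carries the pyridin-3-yl group on a different core; the difference between the two cores is not broken down here. In this assay compound 3 gives the highest number of the three, and its gaps to compound 1 and to compound 2 are both beyond the scatter.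

Compound 4, `CCCCCCCCc1ccc(OCC(=O)Cn2nnnc2-c2ccccn2)cc1`, is not yet measured. It stands to compound 3 as compound 2 stands to compound 1: pyridin-2-yl in place of pyridin-3-yl on an aromatic carbon. The surroundings of the place differ between the two pairs: in the change from compound 1 to compound 2 the carbon is two ring bonds from the ring atom that bears a large group, while in the change from compound 3 to compound 4 it is next to the ring atom that bears a large group. The two are therefore the same kind of change, not the same change.

Going by the values given here, with only one earlier instance, and that one within the scatter, the step of a 1.3-fold lower number from compound 3 to compound 4 (0.10 log units; within the scatter) is expected to be small as well, resting on the step of a 1.3-fold lower number from compound 1 to compound 2 (0.11 log units; within the scatter) observed on the other core. Compound 4 is therefore estimated at 150 nM in this assay, with a range from 60 nM to 400 nM that allows for the different core.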

Compound 4, half-maximal inhibitory concentration: 880 nM
Compound 4: the middle estimate sits 5.9-fold (0.77 log units) below what was measured; the whole stated range lies below it.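

In this assay, pyridin-2-yl in place of pyridin-3-yl on the second core gives a 4.6-fold higher number from compound 3 to compound 4 (0.67 log units; beyond the scatter) and so costs measurable inhibition there. The change cannot be carried from one core to the other as a fixed increment: the same change on two cores in this assay, a 1.3-fold lower number (0.11 log units; within the scatter) from compound 1 to compound 2 and a 4.6-fold higher number (0.67 log units; beyond the scatter) from compound 3 to compound 4, 5.9-fold (0.77 log units) apart, beyond the scatter of two such steps

This pair of steps shows that the core matters for this change, but not which difference between the cores is responsible, and one pair per core gives no rule for any further core. The place of the change also differs, as on the second core the carbon is next to the ring atom that bears a large group, and these four compounds cannot separate that difference from any other difference between the cores.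

On these data alone, it remains open whether pyridin-4-yl or an unsubstituted phenyl group would follow the small step seen on the core of compound 1 or the larger step seen on the core of compound 3. As far as these compounds go, it is also open whether the gap between the two steps would persist with a shorter chain in place of the octyl chain, or with a carboxylic acid at the end of that chain.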